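This account rests on a few compounds, and the source may have more. Where it says the series, first, only, none or still open, it means among the compounds named here.

Of the compounds shown here, three that share one core have been measured in an assay on isolated protein for inhibition of Ectonucleotide pyrophosphatase/phosphodiesterase family member 1 (Homo sapiens), tested at 10 uM; on this read-out higher numbers stand for more inhibition at the one concentration tested (going by the name of the read-out) and lower numbers for less inhibition. Compound 1 `O=C(CSc1nc2cccnc2[nH]1)Nc1cccc(Br)c1` gives 23%, the lowest of the three numbers. Compound 2 `COc1ccc(NC(=O)CSc2nc3ccccc3[nH]2)cc1OC` gives 34%, higher than compound 1 by more than the usual scatter, and compound 3 `COc1ccc(NC(=O)CSc2nc3ccc(N4CCN(C)CC4)nc3[nH]2)cc1OC` gives 35%, also higher than compound 1 by more than the scatter. No two of these three differ in only one place, so no single change can yet be tied to a shift in this assay. Compound 4 `O=C(CSc1nc2cccnc2[nH]1)Nc1ccccc1` differs from compound 1 in one place: hydrogen in place of bromo on an aromatic carbon. Within the data shown here, no measured pair here covers such a change. The step of a number 7 percentage points lower from compound 1 to compound 4 (within the scatter) is expected to be a small fall, within the scatter. Compound 4 is estimated to give 16%, with a range from 4% to 30%.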

Compound 4, a percentage reported as inhibition, at one concentration (the size of the read-out at that concentration, not a potency): 30%
The estimate for compound 4 lay 14 percentage points below the measured number; low and high end bracket the measured number.
By their numbers in this assay, from the lowest: compounds 1, 4, 2 and 3 (each within the scatter of the next, the first and the last beyond it).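

In this assay, among these compounds, the first comparison that differs in one place gives a number 7 percentage points higher from compound 1 to compound 4 (within the scatter), the change being hydrogen in place of bromo on an aromatic carbon. Compound 1 and compound 4 therefore cannot be told apart on this read-out, so the 3-bromophenyl to phenyl change has no clear effect on the shared core. Nothing available explains this result.

From the compounds shown here alone, it remains open whether a different group on this carbon, such as a carboxylic acid or a nitrile, would shift the number beyond the scatter. A single pair also cannot show whether the same change would behave alike on other cores.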